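The compounds below may be only part of what the source reports. "The series", "measured", "known", "first", "only" and "open" are said of these compounds alone.

Measured so far:
compound 1 `CC(C)COc1ccc2c(Cl)ccnc2c1`: 2100 nM
compound 2 `CCOc1ccc2c(Cl)ccnc2c1`: 3340 nM

Among the compounds with values here, in a functional assay on NCI-H1650 cells (Homo sapiens) for cytotoxicity, read by MTT assay, with a stated time of 48 h (a higher number here means a weaker inhibitor, a lower number a stronger inhibitor), compound 2 gives the higher of the two numbers so far, with compound 1 as its only neighbour. Within the data shown here, the single step measured, a 1.6-fold higher number from compound 1 to compound 2 (0.20 log units; within the scatter), is a change of the chain on the ether oxygen of the shared core and stays within the scatter, so the two compounds cannot be ordered.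

Compound 3 `Clc1ccnc2cc(OCCCc3ccccc3)ccc12` differs from compound 2 by benzyl in place of hydrogen on a saturated chain carbon, two bonds along the chain from an oxygen on an aromatic ring. Among the measured compounds shown here, this change also alters only the chain on the ether oxygen, so the step from compound 1 to compound 2 is the one comparison that bears on it, and it was small. With nothing beyond that, compound 3 is expected to move only modestly and, if anywhere, toward a lower number, and the estimated step is a 1.7-fold lower number from compound 2 to compound 3 (0.22 log units; within the scatter). Compound 3 is expected to give about 2000 nM, within 700 nM to 6000 nM.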

Compound 3, half-maximal inhibitory concentration: 630 nM
Compound 3: middle estimate off by 3.2-fold (0.50 log units), on the high side, outside the stated range (below it).
By their numbers in this assay, from the lowest: compound 3; then compounds 1 and 2 (each within the scatter of the next).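

In this assay, the chain on the ether oxygen of the shared core now shows a step beyond the scatter: benzyl in place of hydrogen on a saturated chain carbon, two bonds along the chain from an oxygen on an aromatic ring, gives a 5.3-fold lower number from compound 2 to compound 3 (0.72 log units; beyond the scatter) on one change. The earlier chain change, a 1.6-fold higher number from compound 1 to compound 2 (0.20 log units; within the scatter), stayed within the scatter, so this position can respond to the chain and is not silent as that single step allowed. No measurement at hand accounts for the size of the new step.

Open, as far as these compounds go, is whether the step follows the six-membered aromatic ring or the added chain carbons, which a plain pentyl chain or a cyclohexyl group at the chain end would help to separate. Also open, from the compounds shown here alone, is how an amine or a carboxylic acid at the chain end would read.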